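Hydroxy to Cyano at Two Places on the Same Ring

The source may hold more compounds than are shown below. What is called first, only, known or untested is meant among the compounds shown, and "the series" means these compounds.

Of the compounds shown here, three have been measured in an ADME assay on J774 cells (Mus musculus) for cytotoxicity, read by MTT assay, with a stated time of 48 h, tested at 100 ug/mL; a lower number here means a stronger effect, a higher number a weaker effect of the compound at the concentration tested. Compound 1 `O=C(N/N=C/c1ccccc1O)c1cnccn1` gives 0.3%. Compound 3 `N#Cc1ccccc1/C=N/NC(=O)c1cnccn1` carries cyano in place of hydroxy on an aromatic carbon and gives 75%, a step of a number 74.7 percentage points higher from compound 1 to compound 3 (beyond the scatter). Compound 2 `O=C(N/N=C/c1ccc(O)cc1)c1cnccn1` gives 81%; how its core differs from the core of compound 1 is not broken down here. Compound 4 `N#Cc1ccc(/C=N/NC(=O)c2cnccn2)cc1` has not been measured. Relative to compound 2 it carries cyano in place of hydroxy on an aromatic carbon, the same kind of change as that between compound 1 and compound 3, but at a place para to a large group rather than ortho to a large group. Because compound 2 gives 81% and compound 3 gives 75%, compound 4 is expected to stay near that level, with an estimated step of a number 1 percentage points lower from compound 2 to compound 4 (within the scatter) and an estimated value of 80%, between 60% and 97%.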

Compound 4, a percentage reported as activity, at one concentration (the size of the read-out at that concentration, not a potency): 100%
Compound 4: the middle estimate sits 20 percentage points below what was measured, outside the stated range (above it).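

In this assay, cyano in place of hydroxy on the core of compound 2 gives a number 19 percentage points higher from compound 2 to compound 4 (beyond the scatter). The number rises on both cores, so the direction of the change carries over in these two pairs, but its size does not: the same change on two cores in this assay, a number 74.7 percentage points higher (beyond the scatter) from compound 1 to compound 3 and a number 19 percentage points higher (beyond the scatter) from compound 2 to compound 4, 55.7 percentage points apart, beyond the scatter of two such steps. Two pairs set no rule for further cores, and they cannot tell whether the gap between the steps comes from where the group sits on the ring or from something else.

The compounds shown leave open how other groups at these two places, such as an amine, a carboxylic acid or a longer chain, would read out. They also leave open what changes elsewhere in the molecule would do.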